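Substituting the ring amine of compound 1

The source may report more compounds than this note shows. Statements on the series, on what has been measured and on what is new or still open speak of the compounds shown alone.

Of the compounds shown here, three have so far been measured in a physicochemical assay for solubility, in phosphate buffer, at pH 7.4 (a lower number here means a less soluble compound, a higher number a more soluble compound), and the solubility of compound 1 `CC(C)n1cc(-c2ccnc3[nH]c(C4CCNCC4)cc23)ccc1=O` is the highest of them, at 910000 nM in phosphate buffer. Compound 3 `CC(C)Cn1cc(-c2ccnc3[nH]c(C4CCN(CC(=O)N(C)C)CC4)cc23)ccc1=O` is the nearest with 390000 nM and sits below it, beyond the scatter. Compound 2 `COc1cc(F)ccc1-c1ccnc2[nH]c(C3CCN(CC(=O)N(C)C)CC3)cc12` is the furthest with 38000 nM and also sits below it, beyond the scatter.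

Compound 4 `CC(C)n1cc(-c2ccnc3[nH]c(C4CCN(CC(=O)N5CCCCC5)CC4)cc23)ccc1=O` is still unmeasured. Among the compounds with values here, it keeps the core of compound 1 and carries ((piperidin-1-yl)carbonyl)methyl in place of hydrogen on an amine nitrogen in a ring as its only change.

Within the data shown here, no two measured compounds differ in just one place, so this change has no direct precedent. The guidance is indirect. Compound 2 at 38000 nM and compound 3 at 390000 nM also carry a substituent on that amine nitrogen, and both read lower than compound 1, although they differ from it elsewhere too. A downward step in this assay beyond the scatter is therefore expected. The estimated size of this expected step is a 6.1-fold lower number from compound 1 to compound 4 (0.78 log units; beyond the scatter) on present evidence. Compound 4 is estimated at 150000 nM with an expected range from 40000 nM to 500000 nM until its measurement is available.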

Compound 4, solubility: 79000 nM
The estimate for compound 4 lay 1.9-fold (0.28 log units) above the measured number; the measured number falls inside the stated range.
By their numbers in this assay, from the lowest: compound 2; then compound 4; then compound 3; then compound 1.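

In this assay, ((piperidin-1-yl)carbonyl)methyl in place of hydrogen on an amine nitrogen in a ring gives a 12-fold lower number from compound 1 to compound 4 (1.06 log units; beyond the scatter), the only step shown here that can be read for a single change. Until now, a substituent at this position had been seen only together with changes elsewhere in the molecule. This step shows that, with the rest of compound 1 left as it is, a change at this nitrogen alone comes with a large fall in the number, and no measurement at hand bears on what lies behind it.

The compounds shown leave open which part of the entering group goes with the step: the loss of the hydrogen on the nitrogen, the carbonyl, or the piperidin-1-yl part. A plain methyl on the same nitrogen would address the first of these, while a carboxylic acid or a morpholine amide at the end of the same chain, on the core of compound 1, would show whether the size of the step depends on what stands at the end of that chain.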